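Two Fluorine Patterns on a Shared Core

This account rests on a few compounds, and the source may have more. Where it says the series, first, only, none or still open, it means among the compounds named here.

compound 1 `CN(C(=O)NC(=O)c1ccc(F)c(F)c1)c1nc(C(F)(F)F)c(C(=O)N/N=C/c2ccc(C(F)(F)F)cc2)s1`: 6.07 ug/mL
compound 2 `CN(C(=O)NC(=O)c1ccccc1F)c1nc(C(F)(F)F)c(C(=O)N/N=C/c2cc(C(F)(F)F)cc(C(F)(F)F)c2)s1`: 5.43 ug/mL

Both compounds were tested in a functional assay on A549 cells (Homo sapiens) for inhibition, read by MTT assay, with a stated time of 72 h; on this read-out higher numbers stand for weaker inhibition and lower numbers for stronger inhibition. Compound 2 sits at the low end of the two numbers, yet compound 1 lies within the scatter of it, so the two cannot be told apart. Compound 3 `CN(C(=O)NC(=O)c1ccc(F)c(F)c1)c1nc(C(F)(F)F)c(C(=O)N/N=C/c2cc(C(F)(F)F)cc(C(F)(F)F)c2)s1` is not yet measured; it differs from compound 2 by 3,4-difluorophenyl in place of 2-fluorophenyl on a carbonyl carbon. Going by the values given here, no measured pair shows this change on its own, so its size is unknown. With compound 1 and compound 2 sitting within the scatter of each other, the step from compound 2 to compound 3 is expected to be a 1.0-fold higher number from compound 2 to compound 3 (0.01 log units; within the scatter), none beyond the scatter. Compound 3 is expected to give about 5.6 ug/mL in this assay, ranging from 3 ug/mL to 10.5 ug/mL.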

Compound 3, half-maximal inhibitory concentration: 5.47 ug/mL
Estimate against measurement, compound 3: 1.0-fold (0.01 log units) above, and the stated range covers the measured number.
By their numbers in this assay, from the lowest: compounds 2, 3 and 1 (each within the scatter of the next).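

In this assay, going by these compounds alone, 3,4-difluorophenyl in place of 2-fluorophenyl on a carbonyl carbon gives a 1.0-fold higher number from compound 2 to compound 3 (0.00 log units; within the scatter) and is the first change here seen on its own, with all else held the same. At this position, the two fluorinated phenyl groups cannot be told apart. No other measurement bears on this result.

Only these two fluorinated phenyl groups appear at this position. Going by these compounds, it remains open whether an unsubstituted phenyl, a phenyl carrying an amine or a carboxylic acid, or a longer alkyl chain would give a different number.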